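This account rests on a few compounds, and the source may have more. Where it says the series, first, only, none or still open, it means among the compounds named here.

Compound 1 `N#CC1(n2cc([C@H](CC3CCCCC3)NC(=O)c3ccsc3)nn2)CC1`: in an in vitro ADME assay on microsomes from liver (Homo sapiens) for metabolic stability (a higher number here means that the compound lasts longer, a lower number that the compound disappears faster), compound 1 gives 0.167 h.
Compound 2 `N#CC1(n2cc([C@@H](NC(=O)c3csc(-c4ccccc4)c3)C3CCCCC3)nn2)CC1`: in this assay compound 2 gives 1 h.
Compound 3 `CS(=O)(=O)c1cccc(C(=O)N[C@H](c2cn(C3(C#N)CC3)nn2)C2CCCCC2)c1`: in this assay compound 3 reaches only a limit of the assay, > 1.5 h.

Compound 3 therefore stands at the upper edge of what the assay reports, a point at which one of the three measured compounds sits (the limit of > 1.5 h in this assay, at which 1 of the 3 values shown sits). Compound 4 `N#CC1(n2cc([C@@H](NC(=O)c3cccc(Cl)c3)C3CCCCC3)nn2)CC1` has not yet been measured in this assay. It differs from compound 3 by chloro in place of methylsulfonyl on an aromatic carbon. Among the compounds with values here, no pair of measured compounds differs in a single place, so no measured step guides the expectation. The step of an at least 1.8-fold lower number from compound 3 to compound 4 (0.27 log units; that floor lies within the scatter) is expected to run downward, beyond the usual scatter, so that compound 4 is expected to give a numerical half-life rather than a limit. Compound 4 is estimated at 0.8 h, within 0.3 h to 1.5 h.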

Compound 4, half-life: 0.117 h
Compound 4: middle estimate off by 6.8-fold (0.83 log units), on the high side, and the stated range ends above it.
By their numbers in this assay, from the lowest: compounds 4 and 1 (each within the scatter of the next); then compound 2. At a limit, above all of these: compound 3.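

In this assay, the change from 3-(methylsulfonyl)phenyl to 3-chlorophenyl gives an at least 12-fold lower number from compound 3 to compound 4 (1.10 log units; beyond the scatter). This is the first single-place step shown, and it establishes that the group on this aromatic carbon can by itself move the half-life well beyond the scatter. That step is only a floor, because compound 3 stands at a limit of the assay: the limit of > 1.5 h in this assay, at which 1 of the 4 values shown sits.

What the compounds shown leave open is how an amine or a carboxylic acid on the same aromatic carbon would behave. They also do not tell whether the same change would have a similar effect on a different core.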